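The source may report more compounds than this note shows. Statements on the series, on what has been measured and on what is new or still open speak of the compounds shown alone.

Measured so far in a functional assay on MCF7 cells (Homo sapiens) for cytotoxicity, read by CellTiter-Glo, with a stated time of 5 days; on this read-out lower numbers stand for stronger inhibition and higher numbers for weaker inhibition: compound 1 `CC/C(=C(/c1ccc(/C=C/C(=O)O)cc1)c1ccc2[nH]ncc2c1)c1ccccc1` gives 7.2 nM; compound 2 `COC/C(=C(/c1ccc(/C=C/C(=O)O)cc1)c1ccc2[nH]ncc2c1)c1ccccc1` gives 88 nM; compound 3 `O=C(O)/C=C/c1ccc(/C(=C(\c2ccccc2)C(F)F)c2ccc3[nH]ncc3c2)cc1` gives 14 nM.

Compound 3 sits second highest of the three numbers; the nearest step is a 1.9-fold higher number from compound 1 to compound 3 (0.29 log units; within the scatter), the furthest is a 6.3-fold lower number from compound 2 to compound 3 (0.80 log units; beyond the scatter).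

Compound 4 `O=C(O)/C=C/c1ccc(/C(=C(\c2ccccc2)C(F)(F)F)c2ccc3[nH]ncc3c2)cc1` differs from compound 3 by fluoro in place of hydrogen on a saturated chain carbon bound to a double-bonded chain carbon and two fluorine atoms. Going by the values given here, the one measured step that reworked this same group, a 1.9-fold higher number from compound 1 to compound 3 (0.29 log units; within the scatter), stayed within the scatter, whereas a 12-fold higher number from compound 1 to compound 2 (1.09 log units; beyond the scatter) shows that another swap on the double-bonded chain carbon bound to an aromatic carbon and a double-bonded chain carbon can cost a great deal. Adding one more fluorine is a smaller change than either, so only a small shift in this assay is expected, a 1.4-fold higher number from compound 3 to compound 4 (0.15 log units; within the scatter). Compound 4 is therefore estimated at 20 nM, with a range of 7 nM to 60 nM.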

Compound 4, half-maximal inhibitory concentration: 5.5 nM
For compound 4 the middle estimate is 3.6-fold (0.56 log units) above the measured one; measured number outside the range, below it.
By their numbers in this assay, from the lowest: compounds 4, 1 and 3 (each within the scatter of the next, the first and the last beyond it); then compound 2.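

In this assay, one added fluorine at this position moves the number beyond the scatter (a 2.5-fold lower number from compound 3 to compound 4 (0.41 log units; beyond the scatter)), so even the small change from difluoromethyl to trifluoromethyl counts here. Trifluoromethyl and ethyl stay within the scatter of each other (a 1.3-fold lower number from compound 1 to compound 4 (0.12 log units; within the scatter)), so ethyl can be replaced here with no measurable loss. Methoxymethyl remains the poor fit, now by the widest gap at this position (a 16-fold lower number from compound 2 to compound 4 (1.20 log units; beyond the scatter)).

From the compounds shown here alone, how a nitrile or a longer chain such as propyl would fare here stays open. No measurement shown explains why the added fluorine shifts the number.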